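The source may hold more compounds than are shown below. What is called first, only, known or untested is meant among the compounds shown, and "the series" means these compounds.

Measured in a functional assay on KYSE-410 cells (Homo sapiens) for antiproliferative activity, read by MTT assay, with a stated time of 72 h; a higher number here means a weaker inhibitor, a lower number a stronger inhibitor:
- Compound 1 `O=C(Nc1cccc(F)c1)c1cc(=O)[nH]c2cc(-c3ccsc3)ccc12`: 4300 nM
- Compound 2 `O=C(Nc1cccc(F)c1)c1cc(=O)[nH]c2cc(-c3ccc(F)c(CO)c3)ccc12`: > 20000 nM, a limit and not a number

Compound 2 gives no exact number, only a limit: the limit of > 20000 nM in this assay, at which 1 of the 2 values shown sits. Compound 3 `C#Cc1ccc2c(C(=O)Nc3cccc(F)c3)cc(=O)[nH]c2c1` differs from it in one place: ethynyl in place of 4-fluoro-3-(hydroxymethyl)phenyl on an aromatic carbon. Within the data shown here, the one measured step at this place is an at least 4.6-fold higher number from compound 1 to compound 2 (0.66 log units; beyond the scatter), beyond the scatter, as 4-fluoro-3-(hydroxymethyl)phenyl replaced thiophen-3-yl. Compound 1, without that group, gives 4300 nM, so a move towards a lower number, meaning a stronger inhibitor, is expected once the group leaves. The expected step is an at least 2.8-fold lower number from compound 2 to compound 3 (0.45 log units; beyond the scatter). For compound 3 the estimated value is 7000 nM, with an expected range of 2000 nM to 20000 nM.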

Compound 3, half-maximal inhibitory concentration: 9700 nM
Compound 3: middle estimate off by 1.4-fold (0.14 log units), on the low side, within the range that was stated.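

In this assay, replacing 4-fluoro-3-(hydroxymethyl)phenyl with ethynyl gives an at least 2.0-fold lower number from compound 2 to compound 3 (0.31 log units; beyond the scatter). Compound 2 has only a limit, so that step is a minimum: the limit of > 20000 nM in this assay, at which 1 of the 3 values shown sits. Replacing thiophen-3-yl with ethynyl gives a 2.3-fold higher number from compound 1 to compound 3 (0.35 log units; beyond the scatter), so the ring-free ethynyl does not give the lowest number here, and a ring at this position is not in itself a drawback.

Whether the hydroxymethyl or the fluorine matters more in compound 2 stays open, since a plain phenyl is not among these compounds. From the compounds shown here alone, how an amine or a carboxylic acid would behave at this position also remains open.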